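Cyclopentyl gives way to 3-chlorobenzyl on the ring nitrogen

The source may hold more compounds than are shown below. What is called first, only, known or untested is meant among the compounds shown, and "the series" means these compounds.

In a functional assay (trachea) with Cavia porcellus as the target (on this read-out lower numbers stand for stronger inhibition and higher numbers for weaker inhibition), compound 1 `CCCCCCCCn1nc(-c2cccnc2)c2ccccc2c1=O` gives 21900 nM, while compound 2 `O=c1c2ccccc2c(-c2cccnc2)nn1C1CCCC1` gives 2750 nM, the lower of the two numbers. Compound 3 `O=c1c2ccccc2c(-c2cccnc2)nn1Cc1cccc(Cl)c1` carries 3-chlorobenzyl in place of cyclopentyl on an aromatic nitrogen. Within the data shown here, one measured step bears on this, at the same nitrogen: cyclopentyl in place of octyl gave an 8.0-fold lower number from compound 1 to compound 2 (0.90 log units; beyond the scatter), a modest change. No measured group there contains an aromatic ring, so no step beyond the scatter is expected, and the estimated change is a 1.4-fold lower number from compound 2 to compound 3 (0.14 log units; within the scatter). Compound 3 is expected at 2000 nM, within an estimated range of 400 nM to 10000 nM.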

Compound 3, half-maximal inhibitory concentration: 4170 nM
Estimate against measurement, compound 3: 2.1-fold (0.32 log units) below; measured number inside the range.
By their numbers in this assay, from the lowest: compounds 2 and 3 (each within the scatter of the next); then compound 1.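

In this assay the first aromatic ring at this nitrogen, in 3-chlorobenzyl, gives a result that cannot be told apart from cyclopentyl (a 1.5-fold higher number from compound 2 to compound 3 (0.18 log units; within the scatter)). Against octyl, the 3-chlorobenzyl group still stands clear (a 5.3-fold lower number from compound 1 to compound 3 (0.72 log units; beyond the scatter)), so among these three compounds the position takes a saturated or an aromatic ring alike. Nothing available explains why both ring-bearing groups differ from octyl.

Whether the chlorine contributes remains open, since plain benzyl is absent from the compounds shown. So does the effect of an amine or a carboxylic acid on that ring.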